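A few compounds are considered here, and "the series" means these few. Any claim that something is new, unique, unknown or untested is made for them only; others in the source may bear on it.

Measured so far:
compound 1, `Cc1cc(C(=O)NN2CCOCC2)nn1Cc1cc(Cl)ccc1OCC(C)C` — 251 nM
compound 2, `Cc1cc(NC(=O)C2CCCCC2)nn1Cc1cc(Cl)ccc1OCC(C)C` — 31.6 nM

Going by the values given here, in an assay on CHO-K1 cells for displacement of a labelled ligand from prostaglandin E2 receptor EP1 subtype (Homo sapiens) (on this read-out higher numbers stand for weaker inhibition and lower numbers for stronger inhibition), compound 2 gives 31.6 nM, the lower of the two numbers measured here, and the only neighbour is compound 1, which gives 251 nM. Among the compounds with values here, the single step between them, a 7.9-fold lower number from compound 1 to compound 2 (0.90 log units; beyond the scatter), exchanged the whole amide arrangement on the shared core, and it is the only measured step available.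

Compound 3, `Cc1cc(NC(=O)C2CCCC2)nn1Cc1cc(Cl)ccc1OCC(C)C`, is compound 2 with one change: cyclopentyl in place of cyclohexyl on a carbonyl carbon. The measured step from compound 1 to compound 2 does not bear directly on this change, since it altered how the amide is attached rather than the size of the carbon ring sitting on the carbonyl carbon. Nothing measured here speaks to shrinking that ring by one carbon. Within the data shown here, the expectation is therefore a step of no size beyond the usual scatter in this assay, with no direction claimed, and a wider margin of doubt because the change has no measured precedent. The step this expectation means is a 1.3-fold higher number from compound 2 to compound 3 (0.10 log units; within the scatter). Compound 3 is estimated at 40 nM, within a range from 13 nM to 125 nM.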

Compound 3, half-maximal inhibitory concentration in the prostaglandin E2 receptor EP1 subtype assay: 25.1 nM
Compound 3: the middle estimate sits 1.6-fold (0.20 log units) above what was measured; low and high end bracket the measured number.
By their numbers in the prostaglandin E2 receptor EP1 subtype assay, from the lowest: compounds 3 and 2 (each within the scatter of the next); then compound 1.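

Going by these compounds alone, in the prostaglandin E2 receptor EP1 subtype assay, a 1.3-fold lower number from compound 2 to compound 3 (0.10 log units; within the scatter), so the first measured change to the ring on this carbonyl carbon shows that cyclopentyl and cyclohexyl cannot be told apart here. The amide arrangement also keeps its advantage with the smaller ring, as (cyclopentylcarbonyl)amino in place of (morpholin-4-yl)carbamoyl gives a 10-fold lower number from compound 1 to compound 3 (1.00 log units; beyond the scatter), so that advantage is not tied to cyclohexyl alone. In a physicochemical assay for lipophilicity, at pH 7.4 (on this read-out higher numbers stand for higher lipophilicity and lower numbers for lower lipophilicity), compound 2 gives > 3.7, which is a limit of the assay and not a number. In the physicochemical assay compound 3 gives > 3.7, which is a limit of the assay and not a number, and the step from compound 2 cannot be read because both compounds sit at that limit: the limit of > 3.7 in the physicochemical assay, at which 2 of the 2 values shown sit.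

From the compounds shown here alone, it remains open whether a smaller cyclobutyl or cyclopropyl ring on the same carbonyl carbon, an open chain such as isobutyl, or a ring carrying an amine or a carboxylic acid would stay in the same range in the prostaglandin E2 receptor EP1 subtype assay. Going by these compounds, it is also open whether a ring containing oxygen, such as tetrahydropyranyl, would give a readable number in the physicochemical assay, which any comparison of this change on that read-out would need.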